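Removing the Para Fluoro: Expectation for Compound 4

This account rests on a few compounds, and the source may have more. Where it says the series, first, only, none or still open, it means among the compounds named here.

Measured so far:
- compound 1 `CN(C)C(=O)c1cc2cnc(Nc3ccc(NC(=O)C4(C(=O)Nc5ccc(F)cc5)CC4)cc3)nc2n1C1CCCC1` gives 93.3% in a functional assay on NCI-H1299 cells (Homo sapiens) for inhibition, read by CCK-8 assay, with a stated time of 72 h, tested at 1 uM; a lower number here means less inhibition of growth, a higher number more inhibition of growth at the concentration tested
- compound 2 `CN(C)C(=O)c1cc2cnc(Nc3ccc(NC(=O)C4(C(=O)Nc5ccccc5F)CC4)cc3)nc2n1C1CCCC1` gives 70.2% in this assay
- compound 3 `CN(C)C(=O)c1cc2cnc(Nc3ccc(NC(=O)C4(C(=O)Nc5cccc(Br)c5)CC4)cc3)nc2n1C1CCCC1` gives 46.6% in this assay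

Compound 1 stands highest of the three in this assay, with the others following by a number 23.1 percentage points lower from compound 1 to compound 2 (beyond the scatter) and by a number 46.7 percentage points lower from compound 1 to compound 3 (beyond the scatter). Compound 4 `CN(C)C(=O)c1cc2cnc(Nc3ccc(NC(=O)C4(C(=O)Nc5ccccc5)CC4)cc3)nc2n1C1CCCC1` is the same molecule as compound 1 except for one small change at the amide-type nitrogen: hydrogen in place of fluoro on an aromatic carbon. Here the fluoro leaves and a hydrogen enters, so the ring becomes plain phenyl. Among the compounds with values here, no measured step removes the fluoro outright. The closest guides are the step from the 4-fluorophenyl ring to 2-fluorophenyl, a number 23.1 percentage points lower from compound 1 to compound 2 (beyond the scatter), and to 3-bromophenyl, a number 46.7 percentage points lower from compound 1 to compound 3 (beyond the scatter), both of which lowered the number beyond the scatter once the para position no longer carried fluoro. On that basis a modest drop in this assay is expected for compound 4, of about a number 19.3 percentage points lower from compound 1 to compound 4 (beyond the scatter). Compound 4 is therefore estimated at 74%, within a range from 52% to 92%.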

Compound 4, percent growth inhibition at one concentration: 71.2%
For compound 4 the middle estimate is 2.8 percentage points above the measured one; low and high end bracket the measured number.
By their numbers in this assay, from the lowest: compound 3; then compounds 2 and 4 (each within the scatter of the next); then compound 1.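

In this assay, the fluoro of compound 1 proves to matter in its own right: replacing it with hydrogen gives a number 22.1 percentage points lower from compound 1 to compound 4 (beyond the scatter) and leaves the 4-fluorophenyl ring highest of the four. Plain phenyl also gives a useful baseline: the 2-fluorophenyl ring stands level with it, with a number 1 percentage points higher from compound 2 to compound 4 (within the scatter) in this read-out, whereas the 3-bromophenyl ring stands clearly under it, with a number 24.6 percentage points higher from compound 3 to compound 4 (beyond the scatter) on going to the plain ring. Nothing available here explains why these rings differ.

The rings shown carry only fluoro, bromo or hydrogen, so it remains open whether a chloro, a methoxy group or an amine in the place of the fluoro would hold the number of compound 1 or lose it. On these data alone, how the 3-fluorophenyl ring would compare with the 3-bromophenyl ring also remains open.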